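Solubility notes: acyl-aryl swap on the diaryl urea series

The compounds below may be only part of what the source reports. "The series", "measured", "known", "first", "only" and "open" are said of these compounds alone.

Measured so far in a physicochemical assay for solubility; on this read-out lower numbers stand for lower solubility and higher numbers for higher solubility:
- compound 1 `COc1ccccc1C(=O)NC(=O)Nc1ccc(-c2ccccc2)c(C(F)(F)F)c1` gives < 1 ug/mL, a limit of the assay rather than a number.
- compound 2 `COc1ccccc1C(=O)NC(=O)Nc1ccc(-c2ccccc2)c(C(C)C)c1` gives < 1 ug/mL, also a limit of the assay.
- compound 3 `COc1ccccc1C(=O)NC(=O)Nc1ccc(N2CCCCC2)c(C(F)(F)F)c1` gives 3 ug/mL.

Compound 1 therefore stands at the floor of this assay; the limit of < 1 ug/mL in this assay, at which 2 of the 3 values shown sit, marks where two of the three values sit. The step of an at least 3.0-fold higher number from compound 1 to compound 3 (0.47 log units; beyond the scatter) is the only one that can be read, and it is at least modest. The step that the two limits leave unreadable from compound 1 to compound 2 cannot be sized from two limits.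

Compound 4 `COc1ccncc1C(=O)NC(=O)Nc1ccc(-c2ccccc2)c(C(F)(F)F)c1` differs from compound 1 by 4-methoxypyridin-3-yl in place of 2-methoxyphenyl on a carbonyl carbon. Going by the values given here, neither measured step touches the carbonyl side of the core, so none bears directly on this change; the only readable step sits on the other aromatic ring. With no direct comparator, a small rise out of the limit is expected rather than a large one. The step of an at least 2.0-fold higher number from compound 1 to compound 4 (0.30 log units; that floor lies within the scatter) is the estimate for this change. Compound 4 is thus expected to give about 2 ug/mL in this assay, within 0.5 ug/mL to 8 ug/mL.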

Compound 4, solubility: 17 ug/mL
Compound 4: the middle estimate sits 8.5-fold (0.93 log units) below what was measured; the whole stated range lies below it.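

In this assay, going by these compounds alone, 4-methoxypyridin-3-yl in place of 2-methoxyphenyl on a carbonyl carbon gives an at least 17-fold higher number from compound 1 to compound 4 (1.23 log units; beyond the scatter), so the carbonyl side of the core, which no earlier readable step touched, is a place where one change reads large. The two groups hold the same count of heavy atoms, and the difference is a ring nitrogen in place of a ring carbon, with the methoxy kept. The size of this step is open-ended, since the figure for compound 1 is a limit of the assay and not a number: the limit of < 1 ug/mL in this assay, at which 2 of the 4 values shown sit.

Going by these compounds, whether the same change carries over to the piperidin-1-yl series of compound 3 stays open. So does how the read-out responds on this ring when the methoxy gives way to a dimethylamino group or a longer alkoxy chain.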